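Moving the ring nitrogen on a vinyl sulfone series

The source may report more compounds than this note shows. Statements on the series, on what has been measured and on what is new or still open speak of the compounds shown alone.

Compound 1: `O=S(=O)(/C=C/c1ccccn1)c1ccccc1F` — 1050 nM
Compound 2: `O=S(=O)(/C=C/c1cccnc1)c1ccccc1F` — 6860 nM

Of the compounds shown here, two have been measured in an assay on U2OS cells for activation of nuclear factor erythroid 2-related factor 2 (Homo sapiens), read by beta-arrestin recruitment, with a stated time of 6 h; on this read-out higher numbers stand for an effect only at larger amounts of compound and lower numbers for an effect already at smaller amounts. Compound 1 gives 1050 nM, and compound 2 gives 6860 nM, the highest of the two numbers; the step of a 6.5-fold higher number from compound 1 to compound 2 (0.82 log units; beyond the scatter) is a modest one beyond the scatter. Compound 3 `O=S(=O)(/C=C/c1ccncc1)c1ccccc1F` is not yet measured. It differs from compound 2 in one place: pyridin-4-yl in place of pyridin-3-yl on a double-bonded chain carbon bound to a double-bonded chain carbon. Among the measured compounds shown here, the only measured step, from compound 1 to compound 2, exchanges pyridin-2-yl for pyridin-3-yl and so does not bear directly on the move from pyridin-3-yl to pyridin-4-yl; it shows only that shifting the ring nitrogen can change the number by a modest amount. For the measured compounds named here, with no step of the same kind on record, compound 3 is expected to land close to compound 2, with a slight pull toward a lower number allowed for, a 1.4-fold lower number from compound 2 to compound 3 (0.14 log units; within the scatter). For compound 3 the estimate in this assay is 5000 nM, with a range from 1500 nM to 16000 nM.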

Compound 3, half-maximal effective concentration: 760 nM
Compound 3: the middle estimate sits 6.6-fold (0.82 log units) above what was measured; the measured number lies below the stated range.
By their numbers in this assay, from the lowest: compounds 3 and 1 (each within the scatter of the next); then compound 2.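

In this assay the exchange of pyridin-3-yl for pyridin-4-yl on a double-bonded chain carbon bound to a double-bonded chain carbon gives a 9.0-fold lower number from compound 2 to compound 3 (0.96 log units; beyond the scatter) and so runs opposite in direction to a 6.5-fold higher number from compound 1 to compound 2 (0.82 log units; beyond the scatter) at the same place. The remaining pair gives a 1.4-fold lower number from compound 1 to compound 3 (0.14 log units; within the scatter) and therefore does not separate pyridin-2-yl from pyridin-4-yl on this read-out, even though the ring nitrogen sits differently in the two groups. Among these three compounds, pyridin-3-yl is the one group that stands apart, with a higher number than both others, so moving through the names from pyridin-2-yl to pyridin-3-yl to pyridin-4-yl yields no steady trend but a rise and then a return.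

Nothing available explains why pyridin-3-yl stands apart from the other two groups. Still open, as far as these compounds go, is how a plain phenyl ring, which would show whether the ring nitrogen is needed at all, or a pyrimidin-5-yl group, with a second ring nitrogen, would behave at this place on the chain.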